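Oxazole-fused series: core substituent swap on compound 1

A few compounds are considered here, and "the series" means these few. Any claim that something is new, unique, unknown or untested is made for them only; others in the source may bear on it.

Measured in an ADME assay on the whole organism (Macaca fascicularis) for pharmacokinetics, read by LC-MS, using cassette dosing, at a dose of 1 mg/kg by the oral route; on this read-out lower numbers stand for lower exposure and higher numbers for higher exposure at the dose given:
- compound 1 `CCCCN(c1nc2c(NS(C)(=O)=O)cccc2o1)[C@H](C)c1ccc(-c2ccccc2-c2nnn[nH]2)cc1` gives 73.8 ng.h/mL
- compound 2 `Cc1ccc(-c2nc(=O)o[nH]2)c(-c2ccc([C@@H](C)N(CC3CC3)c3nc4c(C(=O)O)cccc4o3)cc2)c1` gives 4830 ng.h/mL
- compound 3 `CCCCN(c1nc2c(C(=O)O)cccc2o1)[C@H](C)c1ccc(-c2cc(Cl)ccc2-c2nc(=O)o[nH]2)cc1` gives 1040 ng.h/mL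

Compound 1 sits at the bottom of the three numbers in this assay. Compound 3 is the nearest to it and already stands well beyond the scatter above it; compound 2 stands furthest above. Within the data shown here, compounds 2 and 3 differ from compound 1 in several places at once, so no single step between measured compounds can be read off, and the gap to compound 1 cannot be tied to any one change.

Compound 4 `CCCCN(c1nc2c(-c3ccccn3)cccc2o1)[C@H](C)c1ccc(-c2ccccc2-c2nnn[nH]2)cc1` is the untested analogue of compound 1. The difference is pyridin-2-yl in place of methanesulfonamido on an aromatic carbon. The shared core and the remainder of the molecule are unchanged.

Among the measured compounds shown here, no measured pair isolates this change, so the expectation rests on the position of compound 1 alone. The step from compound 1 to compound 4 is expected to be modest, a 2.0-fold higher number from compound 1 to compound 4 (0.31 log units; beyond the scatter), tilted upward but not far enough to be certain of leaving the scatter. Compound 4 is therefore estimated at 150 ng.h/mL in this assay, with a range from 30 ng.h/mL to 800 ng.h/mL.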

Compound 4, area under the concentration-time curve: 248 ng.h/mL
Beside the measured number, compound 4's estimate is 1.7-fold (0.22 log units) below it; low and high end bracket the measured number.
By their numbers in this assay, from the lowest: compound 1; then compound 4; then compound 3; then compound 2.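

In this assay, among these compounds, the only single-place step so far is a 3.4-fold higher number from compound 1 to compound 4 (0.53 log units; beyond the scatter). This shows that the aromatic carbon ortho to a fused ring and meta to a fused ring can change the read-out beyond the scatter through its substituent alone, with the rest of compound 1 held constant. It also shows that methanesulfonamido, with its sulfur and 1 hydrogen-bond donor, is not required there for measurable exposure, since pyridin-2-yl, with 0 hydrogen-bond donors, gives a modest step upward, although no measurement at hand explains the gain.

Among the compounds shown here, the swap changes several features at once, including the sulfur, the hydrogen-bond donor and the six-membered aromatic ring, so the single step cannot assign the gain to any one of them. As far as these compounds go, it remains open whether phenyl, an amino group or a primary carboxamide on the same aromatic carbon would follow pyridin-2-yl, and whether the step would hold with a core carrying a carboxylic acid or an oxadiazolone in place of the tetrazole.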